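Replacing chloro with ethyl in compound 1

This account rests on a few compounds, and the source may have more. Where it says the series, first, only, none or still open, it means among the compounds named here.

Measured in a functional assay on DERL7 cells (Homo sapiens) for antiproliferative activity, with a stated time of 72 h; a higher number here means a weaker inhibitor, a lower number a stronger inhibitor:
- compound 1 `NC(=O)c1cc(-c2ccnc(N)n2)[nH]c1-c1cc(C(F)(F)F)ccc1Cl`: 1880 nM
- compound 2 `NC(=O)c1cc(-c2ccnc(N)n2)[nH]c1-c1cc(OC(F)(F)F)ccc1Cl`: "not determined" (no result reported)
- compound 3 `NC(=O)c1cc(-c2ccnc(N)n2)[nH]c1-c1cc(Cl)ccc1C(F)(F)F`: "not determined" (no result reported)

Among the measured compounds shown here, compound 1 holds the only number in this small set, at 1880 nM. For the measured compounds named here, compound 2 and compound 3 gave no result, so no trend can be read and no step between measured compounds is available for calibration.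

Still unmeasured is compound 4 `CCc1ccc(C(F)(F)F)cc1-c1[nH]c(-c2ccnc(N)n2)cc1C(N)=O`, which keeps the core of compound 1 and carries ethyl in place of chloro on an aromatic carbon, ortho to a large group and para to a trifluoromethyl group (ethyl in place of chloro on an aromatic carbon). With compound 1 at 1880 nM as the sole anchor, the expectation in this assay is a small step towards weaker inhibition, perhaps none beyond the usual scatter, and the direction is uncertain. The estimate means an expected 1.3-fold higher number from compound 1 to compound 4 (0.12 log units; within the scatter). The expected value for compound 4 is 2500 nM, with an estimated range of 800 nM to 7500 nM.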

Compound 4, half-maximal inhibitory concentration in the DERL7 assay: 1470 nM
Compound 4: the middle estimate sits 1.7-fold (0.23 log units) above what was measured, within the range that was stated.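

In the DERL7 assay ethyl in place of chloro on this aromatic carbon, ortho to a large group and para to a trifluoromethyl group, gives a 1.3-fold lower number from compound 1 to compound 4 (0.11 log units; within the scatter) with compound 1 at 1880 nM and compound 4 at 1470 nM and so shows that this position takes either group without a change beyond the scatter. In a physicochemical assay for solubility, at pH 7 (on this read-out higher numbers stand for higher solubility and lower numbers for lower solubility), compound 1 gives 159000 nM and compound 4 gives 182000 nM and the same exchange gives a 1.1-fold higher number from compound 1 to compound 4 (0.06 log units; within the scatter) and likewise stays within the scatter, so neither read-out separates ethyl from chloro here. Nothing at hand explains this result.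

Going by these compounds, whether a longer chain such as propyl, an amine or a carboxylic acid on this carbon would shift the DERL7 assay beyond the scatter stays open. Also open, on these data alone, is whether ethyl in place of chloro would give a similar step with trifluoromethoxy in place of the trifluoromethyl group.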